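A few compounds are considered here, and "the series" means these few. Any claim that something is new, unique, unknown or untested is made for them only; others in the source may bear on it.

Of the compounds shown here, three sharing one core have been tested in a functional assay on U-87MG ATCC cells (Homo sapiens) for cytotoxicity, read by MTT assay, with a stated time of 72 h; on this read-out lower numbers stand for stronger inhibition and higher numbers for weaker inhibition. Compound 1 `CN(C)CCn1cnnc1-c1cc(Oc2ccc(NC(=O)N/N=C/c3c[nH]c4ccccc34)cc2F)ccn1` gives 690 nM. Compound 2 `CN(C)CCn1cnnc1-c1cc(Oc2ccc(NC(=O)N/N=C/c3ccc(F)cc3)cc2F)ccn1` gives 2310 nM. Compound 3 `CN(C)CCn1cnnc1-c1cc(Oc2ccc(NC(=O)N/N=C/c3c(O)ccc4ccccc34)cc2F)ccn1` gives 620 nM, the lowest of the three numbers, though its gap to compound 1 is within the usual scatter; only compound 2 stands clearly apart, as seen in a 3.7-fold lower number from compound 2 to compound 3 (0.57 log units; beyond the scatter).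

Compound 4 `CN(C)CCn1cnnc1-c1cc(Oc2ccc(NC(=O)N/N=C/c3cccc(Br)c3)cc2F)ccn1` is made from compound 3 by one change: 3-bromophenyl in place of 2-hydroxynaphthalen-1-yl on a carbon with a double bond to nitrogen. For the measured compounds named here, no measured step exchanges exactly these two groups, so the closest guides are the steps that swap a fused two-ring group for a single halogen-bearing ring. One such swap, a 3.3-fold higher number from compound 1 to compound 2 (0.52 log units; beyond the scatter), raised the number. The opposite swap, a 3.7-fold lower number from compound 2 to compound 3 (0.57 log units; beyond the scatter), lowered it. Compound 4 moves in the direction of compound 2, exchanging two rings and a hydrogen-bond donor for one ring carrying a bromine, so a step back towards the number of compound 2 is expected, of a modest size rather than a dramatic one, since bromine is not fluorine and the two single-ring compounds need not match.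

Compound 4 is therefore expected to give about 1800 nM in this assay, within a range of 700 nM to 4500 nM, which corresponds to an expected step of a 2.9-fold higher number from compound 3 to compound 4 (0.46 log units; beyond the scatter).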

Compound 4, half-maximal inhibitory concentration: 830 nM
Compound 4: middle estimate off by 2.2-fold (0.34 log units), on the high side; the range from low to high includes it.
By their numbers in this assay, from the lowest: compounds 3, 1 and 4 (each within the scatter of the next); then compound 2.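

In this assay, two steps, a 1.3-fold higher number from compound 3 to compound 4 (0.13 log units; within the scatter) and a 1.2-fold higher number from compound 1 to compound 4 (0.08 log units; within the scatter), show that 3-bromophenyl cannot be told apart from the two-ring groups on the carbon with a double bond to nitrogen, so among these compounds neither a second fused ring nor a hydrogen-bond donor in this group is needed to reach this range of values. A single ring does not settle the outcome either, as the step of a 2.8-fold lower number from compound 2 to compound 4 (0.44 log units; beyond the scatter) separates the two single-ring compounds, which makes the identity of the substituted ring matter more here than the number of rings. No measurement shown here offers a cause for these steps.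

Compound 2 and compound 4 differ in both the halogen and its place on the ring, so the compounds shown cannot tell which of the two accounts for their gap. Also open, as far as these compounds go, is how this position responds to a phenyl ring carrying an amine or a carboxylic acid instead of a halogen.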